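The source may hold more compounds than are shown below. What is called first, only, known or untested is meant among the compounds shown, and "the series" means these compounds.

Compound 1 `O=S(=O)(NCCCNCc1cccc2ccccc12)c1cc(C(F)(F)F)cc(C(F)(F)F)c1` is one of three compounds built on a shared core, each carrying a different aromatic group on a saturated chain carbon bound to an amine nitrogen. In a functional assay on MCF7 cells (Homo sapiens) for inhibition, read by MTT assay, with a stated time of 72 h (a higher number here means a weaker inhibitor of growth, a lower number a stronger inhibitor of growth), compound 1 gives 1400 nM. Compound 3 `O=S(=O)(NCCNCc1ccc(-c2ccccc2)cc1)c1cc(C(F)(F)F)cc(C(F)(F)F)c1` gives 1400 nM in this assay, level with compound 1 at the digits shown, so the two cannot be told apart within the usual scatter. Compound 2 `O=S(=O)(NCCCCNCc1ccc(Br)cc1)c1cc(C(F)(F)F)cc(C(F)(F)F)c1` gives 1500 nM in this assay, and this number too sits within the scatter of the other two, so none of the three measured compounds stands apart from the rest.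

The next compound, compound 4 `CC(C)(C)c1ccc(CNCCCNS(=O)(=O)c2cc(C(F)(F)F)cc(C(F)(F)F)c2)cc1`, is compound 1 with a single change: 4-(tert-butyl)phenyl in place of naphthalen-1-yl on a saturated chain carbon bound to an amine nitrogen. The group that leaves and the group that enters match in what is counted, and neither brings a hydrogen-bond donor or acceptor. Among the measured compounds shown here, the three measured compounds, with three different aromatic groups at this place, all sit within the scatter of one another, and no measured step exists between them. On that basis the step in this assay from compound 1 to compound 4 is expected to be none beyond the scatter. Compound 4 is therefore estimated to give about 1400 nM in this assay, within a range from 600 nM to 3300 nM. The step this estimate implies is no change at the digits printed from compound 1 to compound 4 (within the scatter).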

Compound 4, concentration for 50% growth inhibition: 2100 nM
For compound 4 the middle estimate is 1.5-fold (0.18 log units) below the measured one; measured number inside the range.
By their numbers in this assay, from the lowest: compounds 1, 3, 2 and 4 (each within the scatter of the next).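

In this assay, replacing naphthalen-1-yl with 4-(tert-butyl)phenyl on a saturated chain carbon bound to an amine nitrogen gives a 1.5-fold higher number from compound 1 to compound 4 (0.18 log units; within the scatter), and this is the first step shown in which the compounds differ in only one place. With the rest of the molecule held the same, a group with two aromatic rings can therefore give way to a group with one aromatic ring and a tert-butyl group, of equal heavy-atom count, without a difference that this assay can separate from the scatter of repeated measurements. The data shown offer nothing that would explain this result.

Going by these compounds, both groups in this step are made of carbon only, so it remains open whether a group containing other atoms at this place, such as pyridin-3-yl or 4-carboxyphenyl, would also stay within the scatter. On these data alone, compounds 2 and 3 differ from compound 1 in both the chain and the aromatic group, so the effect of a shorter or longer chain alone, with naphthalen-1-yl kept in place, also remains open.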